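Working notes: side-chain change on compound 2

The compounds below may be only part of what the source reports. "The series", "measured", "known", "first", "only" and "open" are said of these compounds alone.

In an ADME assay on microsomes from liver (Rattus norvegicus) for metabolic stability, using NADPH, with a stated time of 10 min (on this read-out lower numbers stand for a less stable compound and higher numbers for a more stable compound), compound 1 `NCCCCN(C[C@H]1Cc2cccnc2CN1)[C@H]1CCCc2cccnc21` gives 49% and compound 2 `NC/C=C/CN(C[C@H]1Cc2ncccc2CN1)[C@H]1CCCc2cccnc21` gives 11% as the lower of the two numbers, a gap beyond the scatter. Among the measured compounds shown here, no single-place step connects the measured compounds. Compound 3 `CCN(CC)CCCCN(C[C@H]1Cc2ncccc2CN1)[C@H]1CCCc2cccnc21` differs from compound 2 by 3-(diethylamino)propyl in place of 3-aminoprop-1-en-1-yl on a saturated chain carbon bound to an amine nitrogen with 3-(diethylamino)propyl in place of 3-aminoprop-1-en-1-yl on a saturated chain carbon bound to an amine nitrogen. A small upward move is expected in this assay and it may stay within the scatter. The estimated change is a number 9 percentage points higher from compound 2 to compound 3 (within the scatter) on this read-out. Compound 3 is expected at 20% (estimated range 5% to 45%).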

Compound 3, percent of the compound remaining: 6%
For compound 3 the middle estimate is 14 percentage points above the measured one; the measured number falls inside the stated range.
By their numbers in this assay, from the lowest: compounds 3 and 2 (each within the scatter of the next); then compound 1.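

Among the compounds shown here, on a saturated chain carbon bound to an amine nitrogen, 3-(diethylamino)propyl in place of 3-aminoprop-1-en-1-yl gives a number 5 percentage points lower from compound 2 to compound 3 (within the scatter) in this assay, the first single-place step. At this place, going from 4 heavy atoms with a double bond and a hydrogen-bond donor to 8 heavy atoms with neither leaves the read-out within its usual scatter. No available evidence bears on this result.

Open, from the compounds shown here alone, is how a chain ending in a carboxylic acid or an amide would read at this place on the core of compound 2.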